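The compounds below may be only part of what the source reports. "The series", "measured", "known", "first", "only" and "open" are said of these compounds alone.

Measured in an ADME assay (liver, Mus musculus) for metabolic stability, using microsomes; a lower number here means that the compound disappears faster, a higher number that the compound lasts longer:
- compound 1 `C=CC(=O)Nc1cccc(CNc2nc(Nc3cc(F)c(N4CCN(C(C)=O)CC4)c(F)c3)ncc2Cl)c1`: 0.0567 h
- compound 2 `C=CC(=O)Nc1cccc(CNc2nc(Nc3cnn(C4CCN(C(C)=O)CC4)c3)ncc2Cl)c1`: 0.05 h
- compound 3 `C=CC(=O)Nc1cccc(CNc2nc(Nc3cnn(CCOC(F)F)c3)ncc2Cl)c1`: 0.0433 h

Compound 2 at 0.05 h lies within the scatter of both compound 1 and compound 3, so no order can be read among them. Compound 4 `C=CC(=O)Nc1cccc(CNc2nc(Nc3cnn(C(C)(C)COC)c3)ncc2Cl)c1`, not yet measured, differs from compound 2 as follows: 1-(methoxymethyl)-1-methylethyl in place of 1-acetylpiperidin-4-yl on an aromatic nitrogen. The entering group has no ring. Among the compounds with values here, the one measured exchange at this place, with 2-(difluoromethoxy)ethyl entering, gave a 1.2-fold lower number from compound 2 to compound 3 (0.06 log units; within the scatter). On that evidence, no step beyond the scatter is expected in this assay. The expected step is a 1.1-fold lower number from compound 2 to compound 4 (0.03 log units; within the scatter). The estimate for compound 4 is 0.047 h, with an expected range of 0.028 h to 0.085 h.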

Compound 4, half-life: 0.03 h
The estimate for compound 4 lay 1.6-fold (0.19 log units) above the measured number; the measured number falls inside the stated range.
By their numbers in this assay, from the lowest: compounds 4, 3, 2 and 1 (each within the scatter of the next).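

With 1-(methoxymethyl)-1-methylethyl on the aromatic nitrogen, this assay gives a 1.7-fold lower number from compound 2 to compound 4 (0.22 log units; within the scatter) and a 1.4-fold lower number from compound 3 to compound 4 (0.16 log units; within the scatter) so a second group with no ring also stays within the scatter. Across compound 2, compound 3 and compound 4, neither removing the six-membered ring of 1-acetylpiperidin-4-yl nor exchanging one ring-free group for the other gives a readable change in half-life. Nothing available here bears on the cause of these small steps.

Going by these compounds, whether a basic amine, a carboxylic acid or a longer chain at this nitrogen would move the half-life beyond the scatter remains open.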